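This account rests on a few compounds, and the source may have more. Where it says the series, first, only, none or still open, it means among the compounds named here.

Compound 1 `N#C/C=C/c1ccc(Nc2ccnc(Nc3ccc(C#N)cc3)n2)cc1`: > 25000 nM (a limit)
Compound 2 `Cc1cc(/C=C\C#N)cc(C)c1Sc1ccnc(Nc2ccc(C#N)cc2)n1`: > 25000 nM (a limit)
Compound 3 `CCc1cc(/C=C/C#N)cc(C)c1Nc1ccnc(Nc2ccc(C#N)cc2)n1`: 2550 nM

Among the compounds with values here, in an ADME assay on MT4 cells (Homo sapiens) for cytotoxicity, with a stated time of 3 days (a lower number here means that less compound is tolerated, a higher number that more compound is tolerated), compound 3 gives 2550 nM, the only actual number among the three. Compound 1 and compound 2 give no number: each stands at the limit of > 25000 nM in this assay, at which 2 of the 3 values shown sit.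

Compound 4 `Cc1cc(/C=C/C#N)cc(Cl)c1Nc1ccnc(Nc2ccc(C#N)cc2)n1` has chloro in place of ethyl on an aromatic carbon of compound 3: chloro in place of ethyl on an aromatic carbon. Within the data shown here, no measured pair shows this change, so compound 3 at 2550 nM is the starting point. In this assay only a small rise is expected, none beyond the scatter. The expected step is a 1.6-fold higher number from compound 3 to compound 4 (0.20 log units; within the scatter). The estimate for compound 4 is 4000 nM, with an expected range of 1500 nM to 15000 nM.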

Compound 4, half-maximal cytotoxic concentration: 2610 nM
Compound 4: middle estimate off by 1.5-fold (0.19 log units), on the high side, and the stated range covers the measured number.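

In this assay, putting chloro in place of ethyl on this aromatic carbon, ortho to a large group, gives a 1.0-fold higher number from compound 3 to compound 4 (0.01 log units; within the scatter), so the two groups cannot be told apart here. Within the data shown here, this is the first direct comparison at this position, as compound 1 and compound 2 each differ from compound 3 in more than one place. Nothing measured here explains this match. Going by these compounds, whether an amine, a carboxylic acid or a longer chain at this position would also leave the number unmoved stays open.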